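This account rests on a few compounds, and the source may have more. Where it says the series, first, only, none or still open, it means among the compounds named here.

Compound 2 `Cc1cccc(NC(=O)NC2=NC(=O)CN2C)c1` gives 550 nM in a functional assay for inhibition of metabotropic glutamate receptor 5 (Homo sapiens), read by FLIPR and calcium flux (a higher number here means a weaker inhibitor, a lower number a stronger inhibitor), the lowest of the two numbers gathered so far; the nearest is compound 1 `CN1CC(=O)N=C1NC(=O)Nc1cccc(C#N)c1`, which gives 3900 nM in this assay. Among the compounds with values here, the single step between measured compounds, a 7.1-fold lower number from compound 1 to compound 2 (0.85 log units; beyond the scatter), is also the only change at that aromatic carbon that has been examined. Compound 3 `COc1cccc(NC(=O)NC2=NC(=O)CN2C)c1` differs from compound 2 by methoxy in place of methyl on an aromatic carbon. That earlier step bears on it only loosely, as it involved a different pair of groups at the same carbon, but it shows that the group there can shift the number by a modest amount. Within the data shown here, with no direct precedent for methoxy, the step expected here is a 1.8-fold higher number from compound 2 to compound 3 (0.26 log units; within the scatter), a slight move toward a weaker inhibitor that may not exceed the scatter. Compound 3 is therefore estimated at 1000 nM, with a range from 350 nM to 3000 nM.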

Compound 3, half-maximal inhibitory concentration: 2800 nM
Estimate against measurement, compound 3: 2.8-fold (0.45 log units) below; the range from low to high includes it.
By their numbers in this assay, from the lowest: compound 2; then compounds 3 and 1 (each within the scatter of the next).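

In this assay the change from methyl to methoxy at this aromatic carbon gives a 5.1-fold higher number from compound 2 to compound 3 (0.71 log units; beyond the scatter) and is therefore not a neutral exchange. Methoxy in place of cyano gives a 1.4-fold lower number from compound 1 to compound 3 (0.14 log units; within the scatter) and so does not separate these two groups, leaving methyl as the only one of the three that stands apart, with the lowest number. Nothing available here explains why methyl differs from the other two groups.

As far as these compounds go, whether ethyl, a longer chain, or a halogen such as chlorine at this carbon would keep the number of compound 2 remains open. So does whether methyl would keep its lead over methoxy and cyano on another carbon of the aromatic ring.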